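A few compounds are considered here, and "the series" means these few. Any claim that something is new, unique, unknown or untested is made for them only; others in the source may bear on it.

Compound 2 `CC1=C([Se]CC(OC(=O)CNC(=O)OC(C)(C)C)C(=O)NCCCCCC(=O)OCc2ccccc2)C(=O)c2ccccc2C1=O` is measured in a functional assay on A-431 cells (Homo sapiens) for cytotoxicity, read by MTT assay, with a stated time of 24 h (a lower number here means a stronger inhibitor, a higher number a weaker inhibitor), where compound 2 gives 5000 nM. Among the measured compounds shown here, of the three numbers known, this is the second highest; compound 1 `CC1=C([Se]CC(OC(=O)[C@@H](CO)NC(=O)OC(C)(C)C)C(=O)NCCCCCC(=O)OCc2ccccc2)C(=O)c2ccccc2C1=O` gives 4000 nM, compound 3 `CC1=C(SCCC(=O)OC(C[Se]c2ccccc2)C(=O)NC(C)(C)C)C(=O)c2ccccc2C1=O` gives 7000 nM, and both lie within the scatter of compound 2. Compound 4 `CC1=C([Se]CC(OC(=O)CC[Se]c2ccccc2)C(=O)NCCCCCC(=O)OCc2ccccc2)C(=O)c2ccccc2C1=O` differs from compound 2 by a group of 8 heavy atoms (7 carbon, 1 selenium; one six-membered aromatic ring of carbon only) in place of a group of 8 heavy atoms (5 carbon, 1 nitrogen, 2 oxygen; no ring), on a saturated chain carbon bound to a carbonyl carbon. For the measured compounds named here, the only one-place step measured, a 1.3-fold higher number from compound 1 to compound 2 (0.10 log units; within the scatter), concerns another part of the molecule and lies within the scatter, so no measured step bears directly on this change. Compound 3 also contains selenium and a six-membered aromatic ring of carbon only, and its number stays within the scatter of compound 2. Compound 4 is therefore expected to give 5000 nM in this assay, between 2000 nM and 12000 nM. The expected step is no change at the digits printed from compound 2 to compound 4 (within the scatter), no larger than the scatter.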

Compound 4, half-maximal inhibitory concentration: 4000 nM
The estimate for compound 4 lay 1.3-fold (0.10 log units) above the measured number; the measured number falls inside the stated range.
By their numbers in this assay, from the lowest: compounds 1, 4, 2 and 3 (each within the scatter of the next).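

In this assay, putting the group with selenium and a six-membered aromatic ring in place of (tert-butoxycarbonyl)amino, on a saturated chain carbon bound to a carbonyl carbon, gives a 1.3-fold lower number from compound 2 to compound 4 (0.10 log units; within the scatter), so this position takes a group with no hydrogen-bond donors or acceptors without a change beyond the scatter. Exchanging the whole group on the carbonyl carbon gives no change at the digits printed from compound 1 to compound 4 (within the scatter), which is also within the scatter. No measurement is available to explain these results. As far as these compounds go, whether an amine or a carboxylic acid at this position would shift the number beyond the scatter remains open. So does the effect of sulfur in place of selenium in the entering group.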